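Cytotoxicity on liver cells across a pyrimidine ether amide set

The source may hold more compounds than are shown below. What is called first, only, known or untested is meant among the compounds shown, and "the series" means these compounds.

Compound 1 `COc1cccc(Nc2nc3c(c(Oc4cccc(NC(=O)C=C(C)C)c4)n2)CSCC3)c1` carries a 2-methylprop-1-en-1-yl group on the carbonyl carbon of its amide. In an ADME assay on L02 cells (Homo sapiens) for cytotoxicity, read by MTT assay, with a stated time of 72 h (on this read-out lower numbers stand for stronger inhibition and higher numbers for weaker inhibition), compound 1 gives > 50000 nM, which is a limit of the assay and not a number. Compound 2 `COc1cccc(Nc2nc3c(c(Oc4cccc(NC(=O)/C=C/C(C)C)c4)n2)CSCC3)c1` differs from compound 1 by 3-methylbut-1-en-1-yl in place of 2-methylprop-1-en-1-yl on a carbonyl carbon. In this assay compound 2 gives > 50000 nM, again a limit. The step that the two limits leave unreadable from compound 1 to compound 2 therefore cannot be sized. Compound 3 `CC(C)=CC(=O)Nc1cccc(Oc2nc(Nc3cccc(C#N)c3)nc3c2CSCC3)c1` differs from compound 1 in the core by cyano in place of methoxy on an aromatic carbon. In this assay compound 3 gives > 50000 nM, also a limit, so the step that the two limits leave unreadable from compound 1 to compound 3 is likewise unreadable. All three measured compounds sit at the limit of > 50000 nM in this assay, at which 3 of the 3 values shown sit.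

Compound 4 `CC(C)/C=C/C(=O)Nc1cccc(Oc2nc(Nc3cccc(C#N)c3)nc3c2CSCC3)c1` is not yet measured. It differs from compound 3 by 3-methylbut-1-en-1-yl in place of 2-methylprop-1-en-1-yl on a carbonyl carbon. Among the measured compounds shown here, this is the same change as the one from compound 1 to compound 2, made on the same place, a carbonyl carbon whose other neighbour is an amide-type nitrogen, but on the core of compound 3 with its cyano group. From the compounds shown here alone, since the measured step of this change sits between two limits, its size is unknown; the expectation rests on compound 3 at > 50000 nM and compound 2 at > 50000 nM, both limits. In this assay compound 4 is expected to give 60000 nM, with a range from 30000 nM to 120000 nM. The step that the limit leaves unreadable from compound 3 to compound 4 is estimated to be negligible, and a further limit rather than a number is the most likely outcome for compound 4.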

Compound 4, half-maximal inhibitory concentration: > 50000 nM
Compound 4: no number, only a limit; the forecaster's own chance of this, stated with the estimate: 85%; the middle value does not contradict the limit.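

In this assay the steps from compound 3 and from compound 2 to compound 4 cannot be read, as all the values are the same limit of the assay: the limit of > 50000 nM in this assay, at which 4 of the 4 values shown sit.

Left open is whether 3-methylbut-1-en-1-yl in place of 2-methylprop-1-en-1-yl on a carbonyl carbon, or cyano in place of methoxy on an aromatic carbon, changes the read-out at all in this assay.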